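The source may report more compounds than this note shows. Statements on the series, on what has been measured and on what is new or still open speak of the compounds shown alone.

Three compounds share one core. Compound 1 `COc1ccc(-c2cc(=O)c3c(OC)cc(OC)cc3[nH]2)cc1` carries no sulfonyl group at all. In a functional assay on HepG2 cells (Homo sapiens) for antiproliferative activity, with a stated time of 72 h (on this read-out lower numbers stand for an effect already at smaller amounts and higher numbers for an effect only at larger amounts of compound), compound 1 gives only a limit, > 31100 nM. Compound 2 `COc1ccc(-c2cc(=O)c3c(OC)cc(OC)cc3n2S(=O)(=O)c2cccc([N+](=O)[O-])c2)cc1` bears a 3-nitrophenyl on a sulfonyl sulfur, and in this assay compound 2 likewise reaches only a limit, > 39600 nM. Compound 3 `COc1ccc(-c2cc(=O)c3c(OC)cc(OC)cc3n2S(=O)(=O)c2cc(F)c(F)c(F)c2)cc1` carries a 3,4,5-trifluorophenyl there; in this assay compound 3 also shows only a limit, > 65500 nM. Compound 3 thus stands at the limit of > 65500 nM in this assay, at which 1 of the 3 values shown sits, with the other two values resting at limits too. The step that the two limits leave unreadable from compound 2 to compound 3 cannot be read, since the limit of > 39600 nM in this assay, at which 1 of the 3 values shown sits, and the limit of > 65500 nM in this assay, at which 1 of the 3 values shown sits, are both limits. Compound 4 `COc1ccc(-c2cc(=O)c3c(OC)cc(OC)cc3n2S(=O)(=O)c2ccc(Br)s2)cc1` differs from compound 3 as follows: 5-bromothiophen-2-yl in place of 3,4,5-trifluorophenyl on a sulfonyl sulfur. Within the data shown here, the only measured step gives no readable size or direction, so no change beyond the scatter is expected. The expected value for compound 4 in this assay is 60000 nM, within a range from 15000 nM to 250000 nM. That estimate corresponds to an expected step of an at least 1.0-fold lower number from compound 3 to compound 4 (0.03 log units; that floor lies within the scatter).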

Compound 4, half-maximal effective concentration: > 48200 nM
Compound 4: only a limit was reported; the forecaster's own chance of this, stated with the estimate: 80%; the middle value does not contradict the limit.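

Among these compounds, compound 4, like compound 1, compound 2 and compound 3, gives only a limit in this assay, so no step to compound 4 can be read. As far as these compounds go, whether these four compounds truly differ from one another stays open.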